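Replacing Trifluoromethyl with Hydroxy on the Anilino Ring

The source may hold more compounds than are shown below. What is called first, only, known or untested is meant among the compounds shown, and "the series" means these compounds.

Three analogues sharing one core have been measured in a functional assay on HT-29 cells (Homo sapiens) for antiproliferative activity, read by MTT assay, with a stated time of 48 h; on this read-out higher numbers stand for weaker inhibition and lower numbers for stronger inhibition. Compound 1 `O=C(/C=C\Nc1ccc(O)cc1)c1cn(-c2ccccc2)nc1-c1ccccc1` gives 5000 nM in this assay. Compound 2 `O=C(/C=C\Nc1ccc(Cl)cc1)c1cn(-c2ccccc2)nc1-c1ccc(F)cc1` gives 4600 nM. Compound 3 `O=C(/C=C\Nc1ccc(C(F)(F)F)cc1)c1cn(-c2ccccc2)nc1-c1ccc(F)cc1` reaches only a limit of the assay, > 50000 nM, and no number is known for it; it sits at the limit of > 50000 nM in this assay, at which 1 of the 3 values shown sits. For the measured compounds named here, the step of an at least 10-fold higher number from compound 2 to compound 3 (1.03 log units; beyond the scatter) is the only measured step that touches compound 3, and it is large.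

Compound 4 `O=C(/C=C\Nc1ccc(O)cc1)c1cn(-c2ccccc2)nc1-c1ccc(F)cc1` differs from compound 3 by hydroxy in place of trifluoromethyl on an aromatic carbon. Going by the values given here, no measured step describes this exact exchange. The step of an at least 10-fold higher number from compound 2 to compound 3 (1.03 log units; beyond the scatter) shows that the trifluoromethyl compound is far weaker than the chloro compound, and compound 1, which carries the same hydroxy group on the anilino ring but an unsubstituted phenyl on the core, gives 5000 nM, close to the value of compound 2. Compound 4 is therefore expected to fall well below the limit at which compound 3 stands, a step of an at least 10-fold lower number from compound 3 to compound 4 (1.00 log units; beyond the scatter) in the direction of stronger inhibition. Compound 4 is estimated at 5000 nM in this assay, with a range from 1500 nM to 20000 nM.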

Compound 4, half-maximal inhibitory concentration: 1900 nM
For compound 4 the middle estimate is 2.6-fold (0.42 log units) above the measured one; low and high end bracket the measured number.
By their numbers in this assay, from the lowest: compound 4; then compounds 2 and 1 (each within the scatter of the next). At a limit, above all of these: compound 3.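

Hydroxy in place of trifluoromethyl at this position brings the series back from the limit of this assay, giving an at least 26-fold lower number from compound 3 to compound 4 (1.42 log units; beyond the scatter), and the true size of that step stays unknown: the limit of > 50000 nM in this assay, at which 1 of the 4 values shown sits.

Hydroxy also improves on chloro at the same position, with a 2.4-fold lower number from compound 2 to compound 4 (0.38 log units; beyond the scatter), so among compound 2, compound 3 and compound 4, which differ only in this group, the hydroxy compound gives the lowest number. For the compounds shown here, with hydroxy held fixed, the series also shows for the first time what fluoro in place of hydrogen on an aromatic carbon does, a modest change beyond the scatter, with a 2.6-fold lower number from compound 1 to compound 4 (0.42 log units; beyond the scatter).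

The compounds shown leave open whether a free hydroxy is needed at this position, as neither a methoxy group nor an amine stands there in any of them. Going by these compounds alone, they also leave open whether fluoro in place of hydrogen gives a similar step with other groups on the anilino ring, as compound 2 and compound 3 have no counterpart here with an unsubstituted phenyl on the core.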